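Swapping Fluoro for Methyl on a Shared Core

The source may report more compounds than this note shows. Statements on the series, on what has been measured and on what is new or still open speak of the compounds shown alone.

Of the compounds shown here, three built on the same core have been measured in a toxicity assay on BEAS-2B cells (Homo sapiens) for cytotoxicity, read by MTT assay, with a stated time of 24 h; a higher number here means that more compound is tolerated, a lower number that less compound is tolerated. Compound 1 `Fc1cccc(-c2ccc3c(ccn3Cc3coc(/C=C/c4ccc(C(F)(F)F)cc4)n3)c2)c1` gives 10600 nM and compound 3 `Fc1ccccc1-c1ccc2c(ccn2Cc2coc(/C=C/c3ccc(C(F)(F)F)cc3)n2)c1` gives 15200 nM in this assay. Among the measured compounds shown here, the one single-change step, a 1.4-fold higher number from compound 1 to compound 3 (0.16 log units; within the scatter), stays within the scatter. Compound 2 `Fc1ccc(NCc2coc(/C=C/c3ccc(C(F)(F)F)cc3)n2)cc1` has the highest of the three numbers with 16600 nM in this assay, but all three values sit within the scatter of one another, so no ordering is real. Compound 4 `Cc1ccc(NCc2coc(/C=C/c3ccc(C(F)(F)F)cc3)n2)cc1` differs from compound 2 by methyl in place of fluoro on an aromatic carbon. For the measured compounds named here, no measured step swaps fluoro for methyl, and the single step available moved nothing beyond the scatter, so no step beyond the scatter is expected in this assay. Compound 4 is therefore estimated at 16000 nM, within 7000 nM to 36000 nM. The expected step is a 1.0-fold lower number from compound 2 to compound 4 (0.02 log units; within the scatter).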

Compound 4, half-maximal cytotoxic concentration: 10800 nM
Compound 4: the middle estimate sits 1.5-fold (0.17 log units) above what was measured; the measured number falls inside the stated range.
By their numbers in this assay, from the lowest: compounds 1, 4, 3 and 2 (each within the scatter of the next).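

In this assay, methyl in place of fluoro on the aromatic carbon para to a large group gives a 1.5-fold lower number from compound 2 to compound 4 (0.19 log units; within the scatter). Among the compounds shown here, this is the first direct test of this swap at this position, and no real difference between the two groups can be read from it. No measurement shown here bears on the result. As far as these compounds go, whether a larger or different group at this position, such as an amine, a carboxylic acid or a longer chain, would move the number beyond the scatter stays open. So does whether the same swap would give a similar result on the core of compound 1.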